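Methyl Branching of the Chain Bound to a Sulfur

The compounds below may be only part of what the source reports. "The series", "measured", "known", "first", "only" and "open" are said of these compounds alone.

Three compounds share one core and differ only in the chain on a sulfur: compound 1 `CCCCSc1nc(NC2CCCCC2)c2ncn([C@@H]3O[C@H](CO)[C@@H](O)[C@H]3O)c2n1`, compound 2 `CCCSc1nc(NC2CCCCC2)c2ncn([C@@H]3O[C@H](CO)[C@@H](O)[C@H]3O)c2n1` and compound 3 `CCSc1nc(NC2CCCCC2)c2ncn([C@@H]3O[C@H](CO)[C@@H](O)[C@H]3O)c2n1`. In a functional assay on a cell-free system (Platelet, plasma, Homo sapiens) for inhibition, with stated times of 1 min and 3 min (a higher number here means a weaker inhibitor, a lower number a stronger inhibitor), compound 1 gives 83000 nM, compound 2 gives 151000 nM and compound 3 gives 104000 nM. Compound 3 stands second highest of the three, and all three values sit within the usual scatter of one another: a 1.8-fold higher number from compound 1 to compound 2 (0.26 log units; within the scatter), a 1.3-fold higher number from compound 1 to compound 3 (0.10 log units; within the scatter) and a 1.5-fold lower number from compound 2 to compound 3 (0.16 log units; within the scatter). Compound 4 `CC(C)Sc1nc(NC2CCCCC2)c2ncn([C@@H]3O[C@H](CO)[C@@H](O)[C@H]3O)c2n1` is not yet measured; it differs from compound 3 by methyl in place of hydrogen on a saturated chain carbon bound to a saturated chain carbon and a sulfur. Every measured step altered this same chain without moving the number beyond the scatter, so for compound 4 no step beyond the scatter is expected, a 1.1-fold higher number from compound 3 to compound 4 (0.02 log units; within the scatter). Compound 4 is estimated at 110000 nM in this assay, with a range from 50000 nM to 250000 nM.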

Compound 4, half-maximal inhibitory concentration: 187000 nM
The estimate for compound 4 lay 1.7-fold (0.23 log units) below the measured number; low and high end bracket the measured number.
By their numbers in this assay, from the lowest: compounds 1, 3, 2 and 4 (each within the scatter of the next, the first and the last beyond it).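

Going from ethyl to isopropyl gives a 1.8-fold higher number from compound 3 to compound 4 (0.25 log units; within the scatter), and going from propyl to isopropyl gives a 1.2-fold higher number from compound 2 to compound 4 (0.09 log units; within the scatter), so neither step on its own clears the scatter. Only the comparison with the butyl chain does, with a 2.3-fold higher number from compound 1 to compound 4 (0.35 log units; beyond the scatter), a modest step. The methyl does not count the same wherever it sits on the chain, since its removal moves the number in opposite directions at two places: the same change on two cores in this assay, a 1.8-fold higher number (0.26 log units; within the scatter) from compound 1 to compound 2 and a 1.8-fold lower number (0.25 log units; within the scatter) from compound 4 to compound 3, 3.3-fold (0.51 log units) apart, beyond the scatter of two such steps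

From the compounds shown here alone, what a chain longer than butyl, a benzyl group or a chain ending in a carboxylic acid on the sulfur would do in this assay stays open.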